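The source may hold more compounds than are shown below. What is called first, only, known or untested is meant among the compounds shown, and "the series" means these compounds.

Measured so far in a toxicity assay (L6 cells) for cytotoxicity, with Rattus norvegicus as the target, read by resazurin assay, with a stated time of 70 h; a higher number here means a weaker inhibitor, a lower number a stronger inhibitor:

- Compound 1 `N=C(N)c1ccc2nc(-c3ccc(C(=N)N)o3)[nH]c2c1`: 151000 nM
- Compound 2 `CCn1c(-c2ccc(C(=N)N)cc2)nc2cc(C(=N)N)ccc21`: > 207000 nM

For compound 2, the reading of > 207000 nM is a limit of the assay and not a number. It therefore marks where the measurement stops, as the limit of > 207000 nM in this assay, at which 1 of the 2 values shown sits, records, and gives no exact potency for compound 2. Compound 1 gives a numerical reading of 151000 nM.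

The next compound to be tested is compound 3 `N=C(N)c1ccc(-c2nc3cc(C(=N)N)ccc3n2C2CCCCC2)cc1`. It differs from compound 2 by having cyclohexyl in place of ethyl on an aromatic nitrogen. For the measured compounds named here, no measured pair of compounds shows what a change of this kind does in this assay, so the forecast is uncertain. The numerical reading of 151000 nM for compound 1 shows that a compound in this small set can give a number in this high range. A modest move toward stronger inhibition is expected, and the estimated step is an at least 2.0-fold lower number from compound 2 to compound 3 (0.31 log units; beyond the scatter). A second result reported only as a limit remains quite possible. For compound 3, the estimated value is 100000 nM, with an expected range from 25000 nM to 220000 nM.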

Compound 3, half-maximal inhibitory concentration: > 162000 nM
Compound 3 gave a limit, no number; the forecaster's own chance of this, stated with the estimate: 35%; middle value at least 1.6-fold (0.20 log units) away from the limit.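

For the compounds shown here, compound 2 and compound 3 each give only a limit of the assay and not a number, and no step between them can be read in this assay. The compounds shown leave open what numerical reading either compound would give, and what cyclohexyl in place of ethyl on an aromatic nitrogen does to it.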